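The source may report more compounds than this note shows. Statements on the series, on what has been measured and on what is new or still open speak of the compounds shown alone.

Working notes on the series. Both measured compounds share one core and differ only in the group attached to it. Compound 1 `CC(C)n1nc(-c2ccon2)c2c(N)ncnc21` carries a five-membered aromatic ring there; in an assay on TT cells for inhibition of proto-oncogene tyrosine-protein kinase receptor Ret variant C634W (Homo sapiens), read by MTT assay, with a stated time of 10 days (a lower number here means a stronger inhibitor of growth, a higher number a weaker inhibitor of growth), compound 1 gives 7920 nM. Compound 2 `CC(C)n1nc(/C=N/OCc2ccccc2)c2c(N)ncnc21` carries a benzyl oxime ether at the same point; in this assay compound 2 gives 9270 nM. Compound 2 thus sits at the upper end of the two numbers, though its gap to compound 1 lies within the scatter, so the two stand level as weak growth inhibitors.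

Compound 3 `CC(C)n1nc(/C=N/O)c2c(N)ncnc21` differs from compound 2 by hydrogen in place of benzyl on an oxygen. For the measured compounds named here, no measured pair covers this change, so its size cannot be read from the data. The step of a 1.4-fold higher number from compound 2 to compound 3 (0.15 log units; within the scatter) is expected to be small, toward weaker inhibition. Compound 3 is expected to give 13000 nM, with a range from 4500 nM to 40000 nM.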

Compound 3, concentration for 50% growth inhibition: > 10000 nM
Compound 3: a limit, no number; the forecaster's own chance of this, stated with the estimate: 25%; the middle value does not contradict the limit.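

In this assay compound 3 gives > 10000 nM as a limit of the assay and not a number. Hydrogen in place of benzyl on an oxygen gives an at least 1.0-fold higher number from compound 2 to compound 3 (0.03 log units; that floor lies within the scatter) and the smaller open group in place of the five-membered aromatic ring gives an at least 1.2-fold higher number from compound 1 to compound 3 (0.10 log units; that floor lies within the scatter) so neither change shows a gain in growth inhibition, and the true size of either step cannot be read. The benzyl group and the five-membered aromatic ring are thus not yet set apart from the hydrogen oxime, and the reading rests on a floor only: the limit of > 10000 nM in this assay, at which 1 of the 3 values shown sits.

Going by these compounds, how far the group at this point can move growth inhibition stays open. A methyl or a longer chain on the same oxygen, or an amine or a carboxylic acid carried on the benzyl group, would test whether any change here reaches stronger inhibition.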